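The compounds below may be only part of what the source reports. "The series", "measured", "known", "first", "only" and "open" are said of these compounds alone.

Of the compounds shown here, three sharing one core have been tested in a functional assay (QGY7701 cells, Homo sapiens) for inhibition, read by MTT assay, with a stated time of 48 h; on this read-out higher numbers stand for weaker inhibition and lower numbers for stronger inhibition. Compound 1 `COc1ccc(CNC(=O)/C=C/c2coc3cc(O)ccc3c2=O)cc1` gives 10000 nM. Compound 2 `COc1ccc2c(=O)c(/C=C/C(=O)NCc3ccc(F)cc3)coc2c1` gives 7960 nM. Compound 3 `O=C(/C=C/c1coc2cc(O)ccc2c1=O)NCc1ccc(F)cc1` gives only > 100000 nM, which is a limit of the assay rather than a number. Compound 3 therefore stands at the weak end of the three, with its exact position unknown. Two measured steps lead to it: an at least 10-fold higher number from compound 1 to compound 3 (1.00 log units; beyond the scatter) and an at least 12-fold higher number from compound 2 to compound 3 (1.09 log units; beyond the scatter). Both can only be given as minimum sizes because they end at the limit (the limit of > 100000 nM in this assay, at which 1 of the 3 values shown sits).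

Compound 4 `O=C(/C=C/c1coc2cc(O)ccc2c1=O)Nc1ccccc1` is the next compound, differing from compound 3 by phenyl in place of 4-fluorobenzyl on an amide-type nitrogen. Neither measured step touches the group on the amide nitrogen; both concern the substituent on the core. The measured steps thus give no direct guide to this change, and any expectation rests on the weak starting point alone. The expected step is an at least 1.6-fold lower number from compound 3 to compound 4 (0.22 log units; that floor lies within the scatter), which means compound 4 is estimated at 60000 nM in this assay, within a range from 8000 nM to 200000 nM.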

Compound 4, half-maximal inhibitory concentration: 17900 nM
The estimate for compound 4 lay 3.4-fold (0.53 log units) above the measured number; measured number inside the range.
By their numbers in this assay, from the lowest: compounds 2, 1 and 4 (each within the scatter of the next, the first and the last beyond it). At a limit, above all of these: compound 3.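

In this assay, phenyl in place of 4-fluorobenzyl on an amide-type nitrogen gives an at least 5.5-fold lower number from compound 3 to compound 4 (0.74 log units; beyond the scatter). Among the compounds shown here, the earlier steps changed only groups elsewhere on the molecule, so this is the first sign that the group on this nitrogen also matters, with the hydroxyl-bearing core left unchanged. The size of this step is only a minimum, since the value for compound 3 is a limit: the limit of > 100000 nM in this assay, at which 1 of the 4 values shown sits.

The change removes the fluorine and shortens the link to the ring in one move, so the compounds shown cannot say which of the two matters; plain benzyl or a longer chain such as 2-phenylethyl on this nitrogen would help to separate them. Also open, on these data alone, is whether phenyl there has a similar effect when the core carries methoxy instead of hydroxyl.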